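The source may hold more compounds than are shown below. What is called first, only, known or untested is meant among the compounds shown, and "the series" means these compounds.

Measured compounds:
compound 1, `CC1=C(C(=O)Nc2ccc(F)cc2)C(c2ccc([N+](=O)[O-])cc2)n2c(s/c(=C/c3ccccc3Cl)c2=O)=N1`, 19%
compound 2, `CC1=C(C(=O)Nc2ccc(F)cc2)C(c2ccc(Cl)cc2)n2c(s/c(=C/c3ccc(Br)cc3)c2=O)=N1`, 35%
compound 3, `CC1=C(C(=O)Nc2ccc(F)cc2)C(c2ccccc2[N+](=O)[O-])n2c(s/c(=C/c3ccccc3Cl)c2=O)=N1`, 12%

All three were tested in a functional assay on the whole organism (strain albino) for inhibition, with Rattus norvegicus as the target, read by paw edema, with stated times of 1 h and 3 h, at a dose of 25 mg/kg by the oral route; on this read-out higher numbers stand for more inhibition at the one dose given (going by the name of the read-out) and lower numbers for less inhibition. Compound 3 has the lowest of the three numbers, but the gap to its nearest neighbour is only a number 7 percentage points lower from compound 1 to compound 3 (within the scatter), a step that came with 2-nitrophenyl in place of 4-nitrophenyl on a saturated ring carbon and that stays within the usual scatter. Only compound 2, with 35%, lies clearly apart from compound 3.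

Compound 4, `CC1=C(C(=O)Nc2ccc(F)cc2)C(c2ccccc2[N+](=O)[O-])n2c(s/c(=C/c3ccc(Br)cc3)c2=O)=N1`, has not yet been measured. It differs from compound 3 in one place: 4-bromophenyl in place of 2-chlorophenyl on a double-bonded chain carbon bound to an aromatic carbon. For the measured compounds named here, no measured pair differs only in this way, so no step bears directly on it. Compound 2 carries the same 4-bromophenyl group and gives the highest number, but it also differs from compound 3 on the saturated ring carbon, so its value cannot be read as the effect of the bromophenyl alone. Going by the values given here, the one measured step, a number 7 percentage points lower from compound 1 to compound 3 (within the scatter), concerns a different part of the molecule and was small.

Compound 4 is therefore expected to give about 20% in this assay, between 8% and 34%. The expected change, a number 8 percentage points higher from compound 3 to compound 4 (within the scatter), would be a modest rise, quite possibly still within the scatter.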

Compound 4, a percentage reported as inhibition, in the whole organism at one dose (the size of the read-out at that dose, not a potency): 16%
Beside the measured number, compound 4's estimate is 4 percentage points above it; the range from low to high includes it.
By their numbers in this assay, from the lowest: compounds 3, 4 and 1 (each within the scatter of the next); then compound 2.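

For the compounds shown here, for the first time, a change on the double-bonded chain carbon bound to an aromatic carbon can be read directly: in this assay, 4-bromophenyl in place of 2-chlorophenyl gives a number 4 percentage points higher from compound 3 to compound 4 (within the scatter) and so has no effect that stands out from the scatter, at least with 2-nitrophenyl on the saturated ring carbon. On that saturated ring carbon, 2-nitrophenyl in place of 4-chlorophenyl gives a number 19 percentage points lower from compound 2 to compound 4 (beyond the scatter) and thus a step beyond the scatter, which the earlier step at this carbon did not show. With the 4-bromophenyl group held the same, the higher number of compound 2 therefore goes with its 4-chlorophenyl group and cannot be credited to the 4-bromophenyl group alone.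

Still open, from the compounds shown here alone, is whether an amine or a carboxylic acid on the phenyl ring at the saturated ring carbon would raise or lower the number in this assay. No measurement shown here explains why the saturated ring carbon responds to a change while the chain carbon did not in this pair.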